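Aryl swap on the triazole nitrogen: compound 4

The source may report more compounds than this note shows. Statements on the series, on what has been measured and on what is new or still open speak of the compounds shown alone.

Compound 2 `COc1ccccc1-n1nncc1CN1C(=O)C2(C(C#N)=C(N)Oc3c2c2nc4ccccc4nc2c2ccccc32)c2ccccc21` stands at a limit in a functional assay on HepG2 cells (Homo sapiens) for antiproliferative activity, read by MTT assay, with a stated time of 48 h; on this read-out lower numbers stand for stronger inhibition and higher numbers for weaker inhibition: compound 2 gives > 50000 nM, a limit rather than a number. Compound 1 `Cc1ccccc1-n1nncc1CN1C(=O)C2(C(C#N)=C(N)Oc3c2c2nc4ccccc4nc2c2ccccc32)c2ccccc21` gives the same limit, > 50000 nM. Compound 3 `N#CC1=C(N)Oc2c(c3nc4ccccc4nc3c3ccccc23)C12C(=O)N(Cc1cnnn1-c1ccc(S(N)(=O)=O)cc1)c1ccccc12` gives a number, 42200 nM. The change to compound 4 `Cc1ccc(-n2nncc2CN2C(=O)C3(C(C#N)=C(N)Oc4c3c3nc5ccccc5nc3c3ccccc43)c3ccccc32)cc1C` is 3,4-dimethylphenyl in place of 2-methoxyphenyl on an aromatic nitrogen. Bearing on it are the steps a step that the two limits leave unreadable from compound 1 to compound 2 and an at least 1.1-fold lower number from compound 2 to compound 3 (0.07 log units; that floor lies within the scatter), with an at least 1.1-fold lower number from compound 1 to compound 3 (0.07 log units; that floor lies within the scatter) alongside; none shows a readable effect of the group on the aromatic nitrogen, given (the limit of > 50000 nM in this assay, at which 2 of the 3 values shown sit). No step beyond the scatter is therefore expected in this assay, and compound 4 is expected at 50000 nM, between 20000 nM and 150000 nM, most likely again a limit. The expected step of a number no higher from compound 2 to compound 4 (the limit leaves the size open) lies within the scatter.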

Compound 4, half-maximal inhibitory concentration: > 50000 nM
Compound 4 ended at the assay's limit; the forecaster's own chance of this, stated with the estimate: 70%; the middle value lies on the limit itself.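

In this assay, among these compounds, 3,4-dimethylphenyl on the aromatic nitrogen stays at the assay's limit, as do 2-methylphenyl and 2-methoxyphenyl, so replacing the methoxy-bearing aryl group with a carbon-only one gives no readable number. The steps to compound 4 from compound 1 and compound 2 cannot be read, as both ends are limits. The only readable comparison is an at least 1.1-fold higher number from compound 3 to compound 4 (0.07 log units; that floor lies within the scatter), so 4-sulfamoylphenyl is not shown to differ from 3,4-dimethylphenyl.

As far as these compounds go, whether any group on this nitrogen can move the value clearly off the limit remains open. An aryl ring carrying an amine or a carboxylic acid would test this.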